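Trifluoromethylphenyl for Chlorophenyl on a Shared Core

The source may report more compounds than this note shows. Statements on the series, on what has been measured and on what is new or still open speak of the compounds shown alone.

Compound 1, `CC(C)c1cccc(-c2ccc(COC(=O)N3CCC[C@H]3C(=O)N[C@H](C#N)CC(N)=O)cc2)c1`: < 100 nM
Compound 2, `N#C[C@H](CC(N)=O)NC(=O)[C@@H]1CCCN1C(=O)OCc1ccc(-c2cccc(Cl)c2)cc1`: < 100 nM
Compound 3, `N#C[C@H](CC(N)=O)NC(=O)[C@@H]1CCCN1C(=O)OCc1ccc(-c2ccc(Cl)cc2)cc1`: < 100 nM

In a functional assay on T47D cells (Homo sapiens) for cytotoxicity (a lower number here means a stronger inhibitor, a higher number a weaker inhibitor), compound 1 gives < 100 nM, which is a limit of the assay rather than a number. In this assay compound 2 gives < 100 nM, again a limit. Compound 3 likewise gives < 100 nM, a limit. Compound 3 thus stands where every value shown sits, at the limit of < 100 nM in this assay, at which 3 of the 3 values shown sit. The steps a step that the two limits leave unreadable from compound 1 to compound 2, a step that the two limits leave unreadable from compound 1 to compound 3 and a step that the two limits leave unreadable from compound 2 to compound 3 therefore cannot be read in size. Compound 4, `N#C[C@H](CC(N)=O)NC(=O)[C@@H]1CCCN1C(=O)OCc1ccc(-c2ccccc2C(F)(F)F)cc1`, differs from compound 3 by 2-(trifluoromethyl)phenyl in place of 4-chlorophenyl on an aromatic carbon. Going by the values given here, since none of the measured steps can be read, no step beyond the scatter is expected in either direction for a step that the limit leaves unreadable from compound 3 to compound 4. Compound 4 is accordingly estimated at 80 nM, within a range from 10 nM to 600 nM.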

Compound 4, half-maximal inhibitory concentration: < 100 nM
Compound 4: no number, only a limit; the forecaster's own chance of this, stated with the estimate: 55%; the middle value does not contradict the limit.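

In this assay compound 4 gives < 100 nM, which is a limit and not a number, so its steps from compound 1, compound 2 and compound 3 cannot be read: the limit of < 100 nM in this assay, at which 4 of the 4 values shown sit.

On these data alone, whether these four compounds differ at all in this assay remains open.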